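Methyl on the aryl ketone: from compound 3 to compound 4

The source may report more compounds than this note shows. Statements on the series, on what has been measured and on what is new or still open speak of the compounds shown alone.

Compound 1, `Cc1ccc(C(=O)CCc2nnc(-c3ccc([N+](=O)[O-])cc3)o2)cc1`: in a functional assay on the whole organism (strain Wistar) for inhibition, with Rattus norvegicus as the target, with stated times of 30 min and 3 h, at a dose of 20 mg/kg by the oral route (a higher number here means more inhibition at the dose given (going by the name of the read-out), a lower number less inhibition), compound 1 gives 60.5%.
Compound 2, `Cc1ccc(C(=O)CCc2nnc(-c3ccc([N+](=O)[O-])cc3)o2)c(C)c1`: in this assay compound 2 gives 69.1%.
Compound 3, `O=C(CCc1nnc(COc2ccc3ccccc3c2)o1)c1ccccc1`: in this assay compound 3 gives 51%.

Compounds 1 and 2 share a core and differ in one place, (methyl in place of hydrogen on an aromatic carbon). This change made a step of a number 8.6 percentage points higher from compound 1 to compound 2 (within the scatter). The difference between the core of compound 3 and the core of compound 1 is not broken down here; the two values show that compound 3 and compound 1 lie within the scatter of each other, while the gap from compound 3 to compound 2 is beyond it.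

Compound 4, `Cc1ccc(C(=O)CCc2nnc(COc3ccc4ccccc4c3)o2)cc1`, has not yet been measured. It differs from compound 3 by methyl in place of hydrogen on an aromatic carbon. This is the same kind of change as that from compound 1 to compound 2, but the surroundings differ: in compound 2 the entering methyl sits ortho to a large group and meta to a methyl group, whereas in compound 4 it sits para to a large group, on a ring that carries no other methyl.

Beside the measured step of a number 8.6 percentage points higher from compound 1 to compound 2 (within the scatter), the step expected from the same kind of change is a number 6 percentage points higher from compound 3 to compound 4 (within the scatter); this rests on the single example, compound 1 to compound 2, and on the value of compound 3, 51%, as the starting point. The estimate for compound 4 in this assay is 57%, expected to fall between 42% and 72%.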

Compound 4, a percentage reported as inhibition, in the whole organism at one dose (the size of the read-out at that dose, not a potency): 49.4%
Estimate against measurement, compound 4: 7.6 percentage points above; the measured number falls inside the stated range.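

In this assay, replacing phenyl with 4-methylphenyl on the core of compound 3 gives a step of a number 1.6 percentage points lower from compound 3 to compound 4 (within the scatter), so the methyl brings no change that can be told from the usual variation between repeated measurements on this core. Set beside the earlier step on the other core, this new step does not differ from it by more than such variation allows: the same change on two cores in this assay, a number 8.6 percentage points higher (within the scatter) from compound 1 to compound 2 and a number 1.6 percentage points lower (within the scatter) from compound 3 to compound 4, 10.2 percentage points apart, within the scatter of two such steps. This shows that the change carries from one core to the other without a detectable difference in this read-out, but it does not show that the methyl gives a real gain or loss on either core, nor does it rule out a modest dependence on the core, since each core offers a single pair, each step lies within the scatter, and each value is a response at one dose rather than a potency.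

The compounds shown leave open whether any other group in the place of this methyl, such as a chlorine atom, a methoxy group or an amine, would give a step beyond the scatter on either core. They also leave open whether a longer chain between the carbonyl and the shared core would alter the response or the size of the methyl step.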